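The source may report more compounds than this note shows. Statements on the series, on what has been measured and on what is new or still open speak of the compounds shown alone.

Measured so far in a functional assay on HUVEC cells (Homo sapiens) for antiproliferative activity, read by MTT assay, with a stated time of 48 h; on this read-out lower numbers stand for stronger inhibition and higher numbers for weaker inhibition:
- compound 1 `O=[N+]([O-])c1ccc(/C=C/c2nnc(-c3ccc4c(c3)OCCO4)o2)cc1` gives 32100 nM
- compound 2 `Fc1ccccc1/C=C/c1nnc(-c2ccc3c(c2)OCCO3)o1` gives 1160 nM
- compound 3 `Clc1ccc(/C=C/c2nnc(-c3ccc4c(c3)OCCO4)o2)cc1` gives 8030 nM

Compound 3 holds the middle place, second highest of the three numbers. Chloro in place of nitro on an aromatic carbon gives a 4.0-fold lower number from compound 1 to compound 3 (0.60 log units; beyond the scatter), and 4-chlorophenyl in place of 2-fluorophenyl gives a 6.9-fold higher number from compound 2 to compound 3 (0.84 log units; beyond the scatter), both modest in size.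

The next step leads to compound 4 `C(=C/c1nnc(-c2ccc3c(c2)OCCO3)o1)\c1ccccc1`, with hydrogen in place of chloro on an aromatic carbon, para to a large group, which turns 4-chlorophenyl into phenyl: hydrogen in place of chloro on an aromatic carbon. Both measured steps bear on it. Within the data shown here, the first concerns the group on this same aromatic carbon, and the second replaces the same 4-chlorophenyl. Neither shows hydrogen on that carbon, so the data give direction only loosely. Compound 1 with 32100 nM and compound 2 with 1160 nM both suggest that leaving the 4-chlorophenyl need not raise the number, although compound 1 goes against this. A modest step towards lower numbers is therefore expected in this assay, no larger than those seen so far. The expected change is a 2.3-fold lower number from compound 3 to compound 4 (0.36 log units; beyond the scatter), and it may prove smaller. The estimate for compound 4 is 3500 nM, with an expected range from 1000 nM to 14000 nM.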

Compound 4, half-maximal inhibitory concentration: > 50000 nM
Compound 4: no number, only a limit (the forecaster's own chance of this, stated with the estimate: 2%); middle value at least 14-fold (1.15 log units) away from the limit.
By their numbers in this assay, from the lowest: compound 2; then compound 3; then compound 1. At a limit, above all of these: compound 4.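

Compound 4 stands at a limit of the assay and not at a number: the limit of > 50000 nM in this assay, at which 1 of the 4 values shown sits. Removing the substituent therefore does not give a neutral baseline for this series: hydrogen on this aromatic carbon, para to a large group, gives an at least 6.2-fold higher number from compound 3 to compound 4 (0.79 log units; beyond the scatter), and the comparison with the 2-fluorophenyl analogue gives an at least 43-fold higher number from compound 2 to compound 4 (1.63 log units; beyond the scatter), so the plain phenyl compound sits clearly above both halogen-bearing compounds. Nitro goes against any general rule that a substituent on this ring lowers the number, since an at least 1.5-fold higher number from compound 1 to compound 4 (0.19 log units; that floor lies within the scatter) leaves compound 1 not separated from compound 4 with confidence.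

Compound 2 and compound 3 differ in both the halogen and its place on the ring, so the compounds shown do not tell whether the halogen or its position matters more, and a 4-fluorophenyl or a 2-chlorophenyl analogue would separate the two. They also leave open how a methoxy group or an amine on this same aromatic carbon would read, and how far above the limit compound 4 really lies.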